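Methoxy in place of chloro on the indole-bearing core

A few compounds are considered here, and "the series" means these few. Any claim that something is new, unique, unknown or untested is made for them only; others in the source may bear on it.

Measured compounds and their values:
- compound 1 `COC(=O)[C@@]1(C)CCC=C2[C@@H]1CC[C@@H](C)[C@]2(C)Cc1c[nH]c2ccc(OC)cc12`: 3700 nM
- compound 2 `COC(=O)[C@@]1(C)CCC=C2[C@@H]1CC[C@@H](C)[C@]2(C)Cc1c(C)[nH]c2ccc(Br)cc12`: 16000 nM
- compound 3 `COC(=O)[C@@]1(C)CCC=C2[C@@H]1CC[C@@H](C)[C@]2(C)Cc1c(C)[nH]c2ccc(Cl)cc12`: 17000 nM

In a functional assay on T47D cells (Homo sapiens) for inhibition, read by sulforhodamine B assay, with a stated time of 48 h (on this read-out higher numbers stand for weaker inhibition of growth and lower numbers for stronger inhibition of growth), compound 3 gives the highest number of the three, with compound 2 at a value within the scatter of it, while compound 1 stands at a lower number, beyond the scatter. Compound 4 `COC(=O)[C@@]1(C)CCC=C2[C@@H]1CC[C@@H](C)[C@]2(C)Cc1c(C)[nH]c2ccc(OC)cc12` differs from compound 3 by methoxy in place of chloro on an aromatic carbon. Going by the values given here, the only single-place step among the measured compounds is a 1.1-fold higher number from compound 2 to compound 3 (0.03 log units; within the scatter), and it concerns chloro against bromo, not methoxy; it says only that swapping these two groups made no difference beyond the scatter. Among the compounds with values here, compound 1 also carries methoxy and gives a lower number than compound 3, but it differs from compound 3 in a second place as well, so no step is known for the methoxy swap alone. The expectation for compound 4 is therefore a number somewhat lower than that of compound 3, with wide uncertainty, as a 2.1-fold lower number from compound 3 to compound 4 (0.33 log units; beyond the scatter). Compound 4 is thus estimated at 8000 nM, with a range from 3000 nM to 25000 nM.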

Compound 4, concentration for 50% growth inhibition: 15000 nM
Compound 4: the middle estimate sits 1.9-fold (0.27 log units) below what was measured; the range from low to high includes it.
By their numbers in this assay, from the lowest: compound 1; then compounds 4, 2 and 3 (each within the scatter of the next).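

In this assay, methoxy in place of chloro gives a 1.1-fold lower number from compound 3 to compound 4 (0.05 log units; within the scatter) and methoxy in place of bromo gives a 1.1-fold lower number from compound 2 to compound 4 (0.03 log units; within the scatter), so these three groups cannot be told apart at this aromatic carbon, even though methoxy adds a hydrogen-bond acceptor and one more heavy atom than chloro. Going by these compounds alone, the larger difference appears at another place: methyl in place of hydrogen on an aromatic carbon gives a 4.1-fold higher number from compound 1 to compound 4 (0.61 log units; beyond the scatter) and so goes with weaker inhibition of growth, the first single change here to go beyond the scatter. No measurement given here explains either result.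

Going by these compounds, the methyl step rests on this one pair, so it remains open whether it would hold with chloro or bromo in place of methoxy. On these data alone, it is also open whether an amine or a carboxylic acid at the methoxy place would shift the number beyond the scatter.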